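The source may report more compounds than this note shows. Statements on the series, on what has been measured and on what is new or still open speak of the compounds shown alone.

Compound 2: `Cc1ccc(N2CCN(CCNC(=O)c3ccncc3)CC2)cc1`, 316 nM
Compound 1: `COc1ccc(Cl)cc1N1CCN(CCNC(=O)c2cc3ccccc3o2)CC1`, 2340 nM

Both were measured in a functional assay for antagonist activity at Adrenergic receptor alpha-1 (Rattus norvegicus); on this read-out higher numbers stand for weaker binding and lower numbers for tighter binding. Of the two numbers, compound 2 has the lower one with 316 nM, while compound 1 gives 2340 nM; these two structures differ in more than one place, so the gap between them cannot be tied to a single change. Compound 3, `Cc1ccc(N2CCN(CCNC(=O)c3cc4ccccc4o3)CC2)cc1`, is not yet measured. It differs from compound 2 in one place: 1-benzofuran-2-yl in place of pyridin-4-yl on a carbonyl carbon. Within the data shown here, no measured pair shares this single change, so the expectation is guarded. The expected step, a 2.1-fold higher number from compound 2 to compound 3 (0.31 log units; beyond the scatter), is a modest one toward a higher number in this assay, possibly within the scatter. Compound 3 is estimated at 650 nM, within a range from 150 nM to 3000 nM.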

Compound 3, dissociation constant: 120 nM
For compound 3 the middle estimate is 5.4-fold (0.73 log units) above the measured one; measured number below the stated range.
By their numbers in this assay, from the lowest: compound 3; then compound 2; then compound 1.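

In this assay, 1-benzofuran-2-yl in place of pyridin-4-yl on a carbonyl carbon gives a 2.6-fold lower number from compound 2 to compound 3 (0.42 log units; beyond the scatter), so this place accepts the larger group and the number still falls. With that group held fixed, 4-methylphenyl in place of 5-chloro-2-methoxyphenyl on an amine nitrogen in a ring gives a 20-fold lower number from compound 1 to compound 3 (1.29 log units; beyond the scatter), a single change that the earlier pair, differing in more than one place, could not isolate. Nothing at hand explains either step. Going by these compounds, whether a plain phenyl on the carbonyl carbon would stand nearer compound 3 or compound 2 remains open.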